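A Phenoxy Group Replaces the Nitrile in Compound 4

The source may report more compounds than this note shows. Statements on the series, on what has been measured and on what is new or still open speak of the compounds shown alone.

Three compounds share one core and differ only in the substituent on the pendant aromatic ring. Compound 1 `COc1cc(OCc2cccc(CCc3ccccc3)c2)c2cc(-c3cn4nc(OC)sc4n3)oc2c1` carries a phenethyl group and gives 1200 nM in an assay on a cell-free system (plasma) for antagonist activity at proteinase-activated receptor 4 (Homo sapiens), with a stated time of 5 min, in the presence of a further agent that is not named here; a higher number here means a weaker inhibitor, a lower number a stronger inhibitor. Compound 2 `COc1cc(OCc2cccc(COc3ccccc3)c2)c2cc(-c3cn4nc(OC)sc4n3)oc2c1`, with phenoxymethyl in that position, gives 600 nM. Compound 3 `COc1cc(OCc2cccc(C#N)c2)c2cc(-c3cn4nc(OC)sc4n3)oc2c1`, bearing a cyano group, gives 820 nM. Compound 3 thus holds the second highest of the three numbers: its nearest neighbour is compound 2, a 1.4-fold higher number from compound 2 to compound 3 (0.14 log units; within the scatter), and its furthest is compound 1, a 1.5-fold lower number from compound 1 to compound 3 (0.17 log units; within the scatter). Between the other two, a 2.0-fold lower number from compound 1 to compound 2 (0.30 log units; within the scatter). All three steps stay within the scatter, so the numbers give no ordering.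

Compound 4 `COc1cc(OCc2cccc(Oc3ccccc3)c2)c2cc(-c3cn4nc(OC)sc4n3)oc2c1` is not yet measured. Relative to compound 3 it changes as follows: phenoxy in place of cyano on an aromatic carbon. Among the measured compounds shown here, two measured steps bear on this. Compound 2 already carries a phenyl joined through an oxygen and a carbon, and a 1.4-fold higher number from compound 2 to compound 3 (0.14 log units; within the scatter) was within the scatter; compound 1 carries a phenyl on a two-carbon chain, and a 1.5-fold lower number from compound 1 to compound 3 (0.17 log units; within the scatter) was likewise within the scatter. Neither variant moved the number beyond the scatter against the cyano compound, so no step beyond the scatter is expected in this assay. Compound 4 is therefore estimated at 700 nM, between 300 nM and 1600 nM. The expected step is a 1.2-fold lower number from compound 3 to compound 4 (0.07 log units; within the scatter).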

Compound 4, half-maximal inhibitory concentration: 390 nM
Estimate against measurement, compound 4: 1.8-fold (0.25 log units) above, within the range that was stated.
By their numbers in this assay, from the lowest: compounds 4, 2, 3 and 1 (each within the scatter of the next, the first and the last beyond it).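

In this assay, among the compounds shown here, phenoxy on this aromatic carbon gives the first steps at this position that lie beyond the scatter, both modest: (a 2.1-fold lower number from compound 3 to compound 4 (0.32 log units; beyond the scatter)) against the nitrile and (a 3.1-fold lower number from compound 1 to compound 4 (0.49 log units; beyond the scatter)) against the phenethyl group. Among the earlier compounds, no change of substituent here separated one compound from another, so this position now shows that the read-out can respond to the group it carries, though only by a small margin. Phenoxy and phenoxymethyl remain unseparated (a 1.5-fold lower number from compound 2 to compound 4 (0.19 log units; within the scatter)), so the data do not show that joining the phenyl through oxygen alone differs from joining it through oxygen and a carbon, and nothing shown accounts for the steps that do exceed the scatter.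

The compounds shown leave open whether a phenyl joined through an amine or a sulfur atom would behave like phenoxy, and whether substituents such as a chlorine atom or a methoxy group on the terminal phenyl would move the number further. They also leave open whether a carboxylic acid or a longer ether chain at this aromatic carbon would give a step beyond the scatter from compound 4, and whether phenoxy would give the same result on another position of this ring.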